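This account rests on a few compounds, and the source may have more. Where it says the series, first, only, none or still open, it means among the compounds named here.

In an assay on isolated protein for inhibition of Fatty-acid amide hydrolase 1 (Homo sapiens) (a higher number here means a weaker inhibitor, a lower number a stronger inhibitor), compound 1 `CC(C)S(=O)(=O)N1CCC(CCCC(=O)c2ncco2)CC1` gives 140 nM, while compound 2 `O=C(CCCC1CCN(Cc2ccccc2)CC1)c1ncco1` gives 315 nM, the higher of the two numbers, separated by a 2.3-fold higher number from compound 1 to compound 2 (0.35 log units; beyond the scatter). Compound 3 `Cc1cccc(CN2CCC(CCCC(=O)c3ncco3)CC2)c1` differs from compound 2 by methyl in place of hydrogen on an aromatic carbon, a methyl in place of hydrogen on an aromatic carbon. For the measured compounds named here, no measured step bears on this change: the only recorded step swaps the group on the amine nitrogen in a ring and says nothing about the aromatic ring. For compound 3 the step is estimated at a 1.1-fold lower number from compound 2 to compound 3 (0.02 log units; within the scatter), no change beyond the scatter. Compound 3 is expected to give about 300 nM, within a range of 120 nM to 750 nM.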

Compound 3, half-maximal inhibitory concentration: 90 nM
Estimate against measurement, compound 3: 3.3-fold (0.52 log units) above, and the stated range ends above it.
By their numbers in this assay, from the lowest: compounds 3 and 1 (each within the scatter of the next); then compound 2.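

In this assay the change to 3-methylbenzyl gives a 3.5-fold lower number from compound 2 to compound 3 (0.54 log units; beyond the scatter) and shows that this aromatic carbon, where compound 2 carries only hydrogen, responds to the addition of a single methyl. Compared with the isopropylsulfonyl group, the step of a 1.6-fold lower number from compound 1 to compound 3 (0.19 log units; within the scatter) lies within the scatter, so the modest loss seen with plain benzyl does not hold for every benzyl group on this nitrogen. No measurement here explains the gain from the methyl. As far as these compounds go, whether a larger ethyl group, a chlorine atom or a methoxy group would act in the same way at this place stays open.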